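Moving Two Chlorines Around the Phenyl Ring

The source may hold more compounds than are shown below. What is called first, only, known or untested is meant among the compounds shown, and "the series" means these compounds.

Compound 3 `COC(=O)C1=C(C)N=C(C)/C(=C(\O)OC)C1c1cc(Cl)cc(Cl)c1` gives 93.3 nM in a functional assay (muscle tissue) with Cavia porcellus as the target; on this read-out higher numbers stand for an effect only at larger amounts of compound and lower numbers for an effect already at smaller amounts. Among the three measured compounds this is the second highest number. Compound 2 `COC(=O)C1=C(C)N=C(C)/C(=C(\O)OC)C1c1ccccc1I` gives 46.8 nM, and a 2.0-fold higher number from compound 2 to compound 3 (0.30 log units; within the scatter). Compound 1 `COC(=O)C1=C(C)N=C(C)/C(=C(\O)OC)C1c1ccccc1N` gives 39800 nM; a 430-fold lower number from compound 1 to compound 3 (2.63 log units; beyond the scatter), and an 850-fold lower number from compound 1 to compound 2 (2.93 log units; beyond the scatter). Compound 4 `COC(=O)C1=C(C)N=C(C)/C(=C(\O)OC)C1c1ccc(Cl)cc1Cl` differs from compound 3 in one group: 2,4-dichlorophenyl in place of 3,5-dichlorophenyl on a saturated ring carbon. The closest guide is the step between compound 2 and compound 3, where two differently substituted phenyl groups gave numbers within the scatter of each other, while the large steps from compound 1 involve an amino group that is absent here. The expected step is therefore small: a 1.6-fold lower number from compound 3 to compound 4 (0.19 log units; within the scatter). Compound 4 is estimated at 60 nM, with a range from 15 nM to 250 nM.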

Compound 4, half-maximal effective concentration: 640 nM
The estimate for compound 4 lay 11-fold (1.03 log units) below the measured number; measured number above the stated range.
By their numbers in this assay, from the lowest: compounds 2 and 3 (each within the scatter of the next); then compound 4; then compound 1.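

In this assay, compound 3 and compound 4 carry the same atoms, yet 2,4-dichlorophenyl in place of 3,5-dichlorophenyl gives a clear change (a 6.9-fold higher number from compound 3 to compound 4 (0.84 log units; beyond the scatter)), so on this saturated ring carbon the arrangement of the two chlorines on the phenyl ring matters, not just their presence. The 2,4-dichlorophenyl group also falls short of 2-iodophenyl (a 14-fold higher number from compound 2 to compound 4 (1.14 log units; beyond the scatter)) but remains well ahead of 2-aminophenyl (a 62-fold lower number from compound 1 to compound 4 (1.79 log units; beyond the scatter)). Nothing available explains this difference. Still open, from the compounds shown here alone, is how a phenyl ring with a single chlorine, or with a methoxy or nitro group, would compare.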